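This account rests on a few compounds, and the source may have more. Where it says the series, first, only, none or still open, it means among the compounds named here.

Measured compounds:
compound 1 `C[C@@H]1CN([C@@H](C)CO)C(=O)c2cccc(NC(=O)Nc3cncc4ccccc34)c2O[C@H]1CN(C)S(=O)(=O)c1ccc2c(c1)OCCO2` gives 84900 nM
compound 2 `C[C@@H]1CN([C@@H](C)CO)C(=O)c2cccc(NC(=O)Nc3cccc4ccncc34)c2O[C@H]1CN(C)S(=O)(=O)c1ccc2c(c1)OCCO2` gives 101000 nM
compound 3 `C[C@@H]1CN([C@@H](C)CO)C(=O)c2cccc(NC(=O)Nc3nccc4ccccc34)c2O[C@H]1CN(C)S(=O)(=O)c1ccc2c(c1)OCCO2` gives 700 nM

In a physicochemical assay for solubility, read by HPLC, in phosphate buffer, measured as thermodynamic solubility, with a stated time of 24 h, at pH 7.4 (on this read-out higher numbers stand for higher solubility and lower numbers for lower solubility), compound 2 stands highest of the three numbers, though its gap to compound 1 is within the scatter, while compound 3 lies far below it. Compound 4 `C[C@@H]1CN([C@@H](C)CO)C(=O)c2cccc(NC(=O)Nc3ccnc4ccccc34)c2O[C@H]1CN(C)S(=O)(=O)c1ccc2c(c1)OCCO2` is the next member of this series; it differs from compound 2 by one change (quinolin-4-yl in place of isoquinolin-8-yl on an amide-type nitrogen). Two earlier steps bear on this. The step of a 1.2-fold higher number from compound 1 to compound 2 (0.08 log units; within the scatter) shows that moving the ring nitrogen from isoquinolin-4-yl to isoquinolin-8-yl left this assay unchanged. The step of a 140-fold lower number from compound 2 to compound 3 (2.16 log units; beyond the scatter) shows that moving it to isoquinolin-1-yl cut this assay sharply. Quinolin-4-yl places the ring nitrogen in yet another spot, one not covered by the measured steps, so either outcome is possible. For compound 4 the step of a 2.5-fold lower number from compound 2 to compound 4 (0.40 log units; beyond the scatter) is expected, a modest fall that leans toward the behaviour of compound 1 and compound 2 but leaves room for a drop toward compound 3. Compound 4 is therefore estimated at 40000 nM, within 3000 nM to 130000 nM.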

Compound 4, solubility: 30300 nM
Beside the measured number, compound 4's estimate is 1.3-fold (0.12 log units) above it, and the stated range covers the measured number.
By their numbers in this assay, from the lowest: compound 3; then compound 4; then compounds 1 and 2 (each within the scatter of the next).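

In this assay the quinolin-4-yl group on the amide-type nitrogen sets a level of its own: a 3.3-fold lower number from compound 2 to compound 4 (0.52 log units; beyond the scatter) and a 2.8-fold lower number from compound 1 to compound 4 (0.45 log units; beyond the scatter) are both modest steps, while a 43-fold higher number from compound 3 to compound 4 (1.64 log units; beyond the scatter) is a large one. The earlier compounds shown here showed only two outcomes for this position, a number left unchanged or one cut sharply, and this result adds an intermediate outcome. The groups that leave and enter have the same atoms joined differently, so rearranging the ring alone can produce a modest change as well as a large one.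

As far as these compounds go, whether an amine or a carboxylic acid on the quinolin-4-yl group would move this number remains open. No measurement at hand explains why these closely related groups differ.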